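The source may hold more compounds than are shown below. What is called first, only, known or untested is meant among the compounds shown, and "the series" means these compounds.

Working notes on the series, the step from compound 2 to compound 3.

Within the data shown here, compound 2 `CCn1ncc2c(F)cc(-c3ccc(C(CC)(CC)c4nnc(C)[nH]4)c(=O)[nH]3)cc21` carries the methyl-bearing triazole and stands highest of the two numbers so far in a functional assay on CHO cells for antagonist activity at prostaglandin E2 receptor EP3 subtype (Homo sapiens), read by cAMP accumulation; on this read-out lower numbers stand for stronger inhibition and higher numbers for weaker inhibition: compound 2 gives 90 nM. Its nearest neighbour is compound 1 `CCn1ncc2c(F)cc(-c3ccc(C(CC)(CC)c4nnc[nH]4)c(=O)[nH]3)cc21`, which in this assay gives 29 nM. Among the measured compounds shown here, the single measured step, a 3.1-fold higher number from compound 1 to compound 2 (0.49 log units; beyond the scatter), is the only comparison available, and it concerns a methyl in place of hydrogen on an aromatic carbon.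

Compound 3 `CCn1ncc2c(F)cc(-c3ccc(C(CC)(CC)c4nncn4C)c(=O)[nH]3)cc21` is the next member: 4-methyl-4H-1,2,4-triazol-3-yl in place of 5-methyl-4H-1,2,4-triazol-3-yl on a saturated chain carbon bound to an aromatic carbon and two saturated chain carbons. The two structures hold the same atoms, joined differently, so the change is a move of the methyl within the triazole rather than an addition. For the measured compounds named here, no measured step in this assay bears on such a rearrangement; the step from compound 1 to compound 2 speaks only to adding the methyl, not to where it sits. Without a direct precedent, the expectation for compound 3 is a number close to that of compound 2, with no step beyond the scatter in either direction assumed, a 1.1-fold higher number from compound 2 to compound 3 (0.05 log units; within the scatter). Compound 3 is therefore estimated at 100 nM, with a range from 30 nM to 350 nM that is deliberately wide given the absence of a bearing step.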

Compound 3, half-maximal inhibitory concentration: 120 nM
Estimate against measurement, compound 3: 1.2-fold (0.08 log units) below, within the range that was stated.
By their numbers in this assay, from the lowest: compound 1; then compounds 2 and 3 (each within the scatter of the next).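

Moving the methyl within the triazole gives a 1.3-fold higher number from compound 2 to compound 3 (0.12 log units; within the scatter) in this assay, so 5-methyl-4H-1,2,4-triazol-3-yl and 4-methyl-4H-1,2,4-triazol-3-yl are not separated on this read-out, even though the first counts 1 hydrogen-bond donor and the second counts 0. Methyl in place of hydrogen on an aromatic nitrogen gives a 4.1-fold higher number from compound 1 to compound 3 (0.62 log units; beyond the scatter), so among these three compounds a methyl on either an aromatic carbon or an aromatic nitrogen of the triazole goes with a higher number than the unsubstituted ring of compound 1, with no compound going against this. No evidence in hand accounts for either step.

Open, going by these compounds, is whether the higher number belongs to methyl alone or extends to other triazole substituents such as ethyl, cyclopropyl or an amine. Also open, on these data alone, is how far this position on a saturated chain carbon bound to an aromatic carbon and two saturated chain carbons tolerates replacing the triazole itself, for instance with a carboxylic acid or a primary amide.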